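Naphthalen-1-yl to 2-methoxyphenyl in compound 1

The compounds below may be only part of what the source reports. "The series", "measured", "known", "first", "only" and "open" are said of these compounds alone.

In a functional assay on HCT-116 cells (Homo sapiens) for inhibition, read by sulforhodamine B assay, with a stated time of 48 h, tested at 50 uM (a lower number here means less inhibition of growth, a higher number more inhibition of growth at the concentration tested), compound 1 (`COc1cc(/C=C/C(=O)/C=C/c2cccc3ccccc23)ccc1OCc1cn(CCOc2cc(=O)oc3ccccc23)nn1`) gives 83% and stands highest of the three measured compounds, beyond the scatter from both others. Compound 2 (`COc1ccc(/C=C/C(=O)/C=C/c2ccc(OCc3cn(CCCCCOc4cc(=O)oc5ccccc45)nn3)c(OC)c2)cc1OC`) gives 45% and compound 3 (`COc1ccc(/C=C/C(=O)/C=C/c2ccc(OCc3cn(CCCOc4cc(=O)oc5ccccc45)nn3)c(OC)c2)cc1`) gives 54% as well, two values within the scatter of each other. Within the data shown here, neither carries naphthalen-1-yl, but each also differs from compound 1 elsewhere, so no single-change step is available.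

The unmeasured compound 4 (`COc1ccccc1/C=C/C(=O)/C=C/c1ccc(OCc2cn(CCOc3cc(=O)oc4ccccc34)nn2)c(OC)c1`) has 2-methoxyphenyl in place of naphthalen-1-yl on a double-bonded chain carbon bound to a double-bonded chain carbon and otherwise matches compound 1. A fall in this assay is expected, on the weak guide that compound 3 gives 54% without naphthalen-1-yl. The estimated step is a number 18 percentage points lower from compound 1 to compound 4 (beyond the scatter) and is expected to lie beyond the scatter, though with wide uncertainty. In this assay the estimate for compound 4 is 65% with an expected range from 47% to 83% as the working expectation.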

Compound 4, percent growth inhibition at one concentration: 70%
Compound 4: middle estimate off by 5 percentage points, on the low side; low and high end bracket the measured number.
By their numbers in this assay, from the lowest: compounds 2 and 3 (each within the scatter of the next); then compound 4; then compound 1.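

At this position, on a double-bonded chain carbon bound to a double-bonded chain carbon, the series now has its first single-change step in this assay: 2-methoxyphenyl in place of naphthalen-1-yl gives a number 13 percentage points lower from compound 1 to compound 4 (beyond the scatter), a modest step. Growth inhibition is therefore reduced but not lost when this group changes, with compound 4 at 70% while the rest of compound 1 stays the same. Nothing available explains the size of this step.

A single step cannot separate the loss of one aromatic ring from the gain of the methoxy group, since both occur together in this change. Plain phenyl, naphthalen-2-yl or 2-aminophenyl at this position would be needed to show which part of the change matters, and how far the position accepts other groups remains open.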